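The source may report more compounds than this note shows. Statements on the series, on what has been measured and on what is new or still open speak of the compounds shown alone.

Compound 1 `CCc1cc(S(=O)(=O)N2C[C@H](c3ccccc3)NC2=O)ccc1NC(=O)c1ccc(N)cc1` is one of two compounds with a shared core measured in a functional assay on A549 cells (Homo sapiens) for cytotoxicity, read by MTT assay; a lower number here means a stronger inhibitor, a higher number a weaker inhibitor. In that assay compound 1 gives 220 nM, which is the higher of the two numbers. The other is compound 2 `CCOC(=O)Nc1ccc(S(=O)(=O)N2C[C@H](c3ccccc3)NC2=O)cc1C`, and in this assay compound 2 gives 50 nM; the gap between the two lies beyond the usual scatter of repeated measurements, so compound 2 is the stronger inhibitor of the pair.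

Compound 3 `CCc1cc(S(=O)(=O)N2C[C@H](c3ccccc3)NC2=O)ccc1NC(=O)OC` has not yet been measured in this assay. It differs from compound 1 in one place: methoxy in place of 4-aminophenyl on a carbonyl carbon. Put another way, the (4-aminophenyl)carbonyl becomes a methoxycarbonyl, so the group on the amide-type nitrogen becomes a (methoxycarbonyl)amino. Among the measured compounds shown here, no step between two measured compounds matches this change, so the expectation rests on the two values shown. Because compound 2 gives 50 nM with its own carbonyl-bearing group on the ring nitrogen, a lower number for compound 3 than for compound 1 is expected, a step of a 3.4-fold lower number from compound 1 to compound 3 (0.53 log units; beyond the scatter) beyond the scatter. For compound 3 the estimate in this assay is 65 nM, with a range from 25 nM to 170 nM.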

Compound 3, half-maximal inhibitory concentration: 250 nM
Compound 3: the middle estimate sits 3.8-fold (0.59 log units) below what was measured; measured number outside the range, above it.
By their numbers in this assay, from the lowest: compound 2; then compounds 1 and 3 (each within the scatter of the next).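

In this assay, replacing the 4-aminophenyl on the carbonyl carbon with methoxy gives a 1.1-fold higher number from compound 1 to compound 3 (0.06 log units; within the scatter). This is a large change in structure: a group with a six-membered aromatic ring and a hydrogen-bond donor gives way to a much smaller one with neither, yet the number does not move beyond the scatter. For this pair, then, the aromatic ring and its amine are not needed to keep the number at this level, and the carbonyl on the amide-type nitrogen, present in both compounds, can carry very different groups; nothing available here explains why the two groups read alike.

One pair cannot show whether this tolerance extends to other groups on the same carbonyl carbon, such as a dimethylamino group, a tert-butoxy group or a longer chain like butoxy. Compound 2 differs from compound 3 in more than one place, so the compounds shown cannot assign its value to any single change, and a matched pair with only the ethoxy or only the ring methyl altered would be needed.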